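Compound 2 to compound 3: methyl swapped for cyclopropyl

The source may report more compounds than this note shows. Statements on the series, on what has been measured and on what is new or still open speak of the compounds shown alone.

Compound 1 `O=c1[nH]nc(Cc2ccc(Cl)cc2)n1/N=C/c1ccc(O)c(O)c1`: 0.026 ug/mL
Compound 2 `Cc1n[nH]c(=O)n1/N=C/c1ccc(O)c(O)c1`: 0.025 ug/mL

Among the measured compounds shown here, in a physicochemical assay (on this read-out lower numbers stand for stronger inhibition and higher numbers for weaker inhibition), compound 2 gives 0.025 ug/mL and stands within the scatter of compound 1, the only other measured compound. Compound 3 `O=c1[nH]nc(C2CC2)n1/N=C/c1ccc(O)c(O)c1` carries cyclopropyl in place of methyl on an aromatic carbon. For the measured compounds named here, the one measured step, a 1.0-fold lower number from compound 1 to compound 2 (0.02 log units; within the scatter), involves a larger group at this carbon and stays within the scatter. On that single step, no change beyond the scatter is expected. The estimated step is a 1.1-fold higher number from compound 2 to compound 3 (0.05 log units; within the scatter). Compound 3 is expected at 0.028 ug/mL, with an estimated range of 0.014 ug/mL to 0.055 ug/mL.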

Compound 3, half-maximal inhibitory concentration: 0.05 ug/mL
Estimate against measurement, compound 3: 1.8-fold (0.25 log units) below; the range from low to high includes it.
By their numbers in this assay, from the lowest: compounds 2, 1 and 3 (each within the scatter of the next).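

At this aromatic carbon, a ring directly on the core is now covered in this assay: cyclopropyl in place of methyl gives (a 2.0-fold higher number from compound 2 to compound 3 (0.30 log units; within the scatter)) and cyclopropyl in place of 4-chlorobenzyl gives (a 1.9-fold higher number from compound 1 to compound 3 (0.28 log units; within the scatter)). Methyl, cyclopropyl and 4-chlorobenzyl thus all lie within the scatter of one another, so no preference among these three groups can be read at this position. No evidence at hand bears on this result. On these data alone, whether an amine or a carboxylic acid at this carbon would move the number beyond the scatter stays open.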